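This account rests on a few compounds, and the source may have more. Where it says the series, first, only, none or still open, it means among the compounds named here.

The series rests on a shared core, seen in compound 1 `CCc1ccccc1NS(=O)(=O)c1ccc(N2CCNC2=O)cc1`, in which a substituted aniline is joined through a sulfonamide to the aryl that carries the cyclic urea. In a functional assay on MCF7 cells (Homo sapiens) for antiproliferative activity, read by sulforhodamine B assay, with a stated time of 48 h (a higher number here means a weaker inhibitor, a lower number a stronger inhibitor), compound 1 gives 350 nM. Compound 2 `O=C1NCCN1c1ccc(S(=O)(=O)Nc2ccc(C3CCCCC3)cc2)cc1` carries a cyclohexyl on the aniline ring instead of the ethyl of compound 1. In this assay compound 2 gives > 1000 nM, which is a limit of the assay and not a number. For the measured compounds named here, compound 2 therefore stands at the edge of what the assay can report, as described by the limit of > 1000 nM in this assay, at which 1 of the 2 values shown sits, while compound 1 is the only member with a measured number.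

Compound 3 `O=C1NCCN1c1ccc(S(=O)(=O)Nc2ccccc2)cc1` differs from compound 2 in one place: hydrogen in place of cyclohexyl on an aromatic carbon. Going by the values given here, no step between measured compounds accompanies this change, so its size has to be judged from the two values alone. Since compound 2 stands only at a limit, the step from compound 2 to compound 3 is expected to be a step that the limit leaves unreadable from compound 2 to compound 3, toward a stronger inhibitor, though a further limit remains quite possible. Compound 3 is therefore expected to give about 1500 nM, with a likely range from 400 nM to 5000 nM.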

Compound 3, half-maximal inhibitory concentration: 470 nM
Compound 3: the middle estimate sits 3.2-fold (0.50 log units) above what was measured; low and high end bracket the measured number.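

On this aromatic carbon, hydrogen in place of cyclohexyl gives an at least 2.1-fold lower number from compound 2 to compound 3 (0.32 log units; beyond the scatter) in this assay, so the bare aniline ring of compound 3 returns a measured number where the cyclohexyl compound gave none. Hydrogen in place of ethyl gives a 1.3-fold higher number from compound 1 to compound 3 (0.13 log units; within the scatter), so the ethyl of compound 1 brings no readable gain over hydrogen, and of the two groups only cyclohexyl is accompanied by a step beyond the scatter. The true size of the cyclohexyl step stays unknown and can only be larger than printed, because compound 2 stands at a limit of the assay and not at a number: the limit of > 1000 nM in this assay, at which 1 of the 3 values shown sits.

The compounds shown leave open whether a smaller group on the carbon that carries the cyclohexyl, such as a methyl or a methoxy, would already raise the number, or whether only a group as large as the cyclohexyl does so, and whether an amine or a carboxylic acid there would move it at all. They also do not tell how the ethyl itself, or a longer chain, would read on that same carbon.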